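The source may report more compounds than this note shows. Statements on the series, on what has been measured and on what is new or still open speak of the compounds shown alone.

Measured so far:
- compound 1 `Cc1cc(C)c(CN2CCc3c(Cl)cc([C@@H](CO)[C@@H]4CCCO4)c(Cl)c3C2=O)c(=O)[nH]1`: 550000 nM
- compound 2 `COC(c1cc(Cl)c2c(c1Cl)C(=O)N(Cc1c(C)cc(C)[nH]c1=O)CC2)C1CCN(C(C)=O)CC1`: 532000 nM; 498000 nM (2 entries)
- compound 3 `COc1cc(C)[nH]c(=O)c1CN1CCc2c(Cl)cc([C@@H](O)C3COC3)c(Cl)c2C1=O`: 582000 nM

In a physicochemical assay for solubility, measured as kinetic solubility (on this read-out lower numbers stand for lower solubility and higher numbers for higher solubility), compound 1 gives 550000 nM. Compound 3, at 582000 nM, sits within the scatter of compound 1, so no order between the two can be read from these numbers. Compound 2 has been run more than once, and the several entries of compound 2 in this assay, 532000 nM; 498000 nM (2 entries) shows how closely the repeats of one compound agree here; all three measured compounds lie in a narrow band.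

Compound 4 `Cc1cc(C)c(CN2CCc3c(Cl)cc([C@H](C)CO)c(Cl)c3C2=O)c(=O)[nH]1` is not yet measured in this assay. It differs from compound 1 in one place: methyl in place of oxolan-2-yl on a saturated chain carbon bound to an aromatic carbon and a saturated chain carbon. Within the data shown here, no step between two measured compounds with a change of this kind is available, so the expected size of the step rests only on the band in which compounds 1, 2 and 3 fall.

The expectation is that compound 4 stays in that band, with a step from compound 1 of no change at the digits printed from compound 1 to compound 4 (within the scatter) that does not exceed the scatter in either direction. For compound 4 the estimated value in this assay is 550000 nM, with a range from 400000 nM to 700000 nM.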

Compound 4, solubility: 131000 nM
Estimate against measurement, compound 4: 4.2-fold (0.62 log units) above; measured number below the stated range.
By their numbers in this assay, from the lowest: compound 4; then compounds 1 and 3 (each within the scatter of the next).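

In this assay, methyl in place of oxolan-2-yl on a saturated chain carbon bound to an aromatic carbon and a saturated chain carbon gives a 4.2-fold lower number from compound 1 to compound 4 (0.62 log units; beyond the scatter). Among these compounds, this is the first single-place step, and it shows that the number at this position can leave the narrow band held by the earlier compounds. The exchange removes a five-membered non-aromatic ring with 1 hetero atom, 1 hydrogen-bond acceptor and 1 defined stereocentre, and the step stands well clear of how closely repeats agree in this assay: the several entries of compound 2 in this assay, 532000 nM; 498000 nM (2 entries)

All of these differences travel together in one exchange, so this single step cannot assign the drop to the ring, the oxygen, the heavy-atom count or the stereocentre. As far as these compounds go, an open ether chain such as methoxyethyl, an amine or a carboxylic acid at the same carbon would help separate these features, and whether the same exchange gives a step of similar size on a compound other than compound 1 remains open.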